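A Methoxy Group Added to a Weakly Active Thiazole Amide

This account rests on a few compounds, and the source may have more. Where it says the series, first, only, none or still open, it means among the compounds named here.

compound 1 `Cc1nc(SCC(=O)Nc2nc(-c3ccc(Cl)cc3)cs2)n(Nc2ccccc2)c1C`: > 100000 nM
compound 2 `Cc1ccc(Nn2c(SCC(=O)Nc3nc(-c4ccccc4)cs3)nc(C)c2C)cc1`: 99300 nM

Both measured compounds were tested in a functional assay on CAKI-1 cells (Homo sapiens) for antiproliferative activity, read by sulforhodamine B assay, with a stated time of 48 h; a lower number here means that less compound is tolerated, a higher number that more compound is tolerated. For compound 1 the result > 100000 nM is a limit of the assay, not a number: the limit of > 100000 nM in this assay, at which 1 of the 2 values shown sits. Compound 2 gives 99300 nM, a figure at the very edge of what this assay resolves. Together the two values show only weak growth inhibition at the concentrations tested.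

Compound 3 `COc1ccc(Nn2c(SCC(=O)Nc3nc(-c4ccc(Cl)cc4)cs3)nc(C)c2C)cc1` has not yet been measured. It differs from compound 1 in a single place: methoxy in place of hydrogen on an aromatic carbon, on an aromatic carbon of a six-membered aromatic ring of carbon only, para to a large group. Within the data shown here, no pair of measured compounds that differ in one place is available to gauge this change. Because compound 1 already sits at the limit > 100000 nM, little movement is anticipated. The expected step of a number no higher from compound 1 to compound 3 (the limit leaves the size open) is small and in no clear direction, within the usual scatter. Compound 3 is estimated at 100000 nM, within 40000 nM to 250000 nM, with a real chance that this assay again reports only a limit.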

Compound 3, concentration lethal to 50% of the cells: > 100000 nM
Compound 3: only a limit was reported; the forecaster's own chance of this, stated with the estimate: 55%; the middle value sits exactly at the limit.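

Among these compounds, no step from compound 1 to compound 3 can be read, because both results are limits of the assay and not numbers: the limit of > 100000 nM in this assay, at which 2 of the 3 values shown sit. The compounds shown leave open whether methoxy in place of hydrogen on an aromatic carbon changes growth inhibition at all, and by how much.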